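From piperazin-1-yl to bromo on the shared core

A few compounds are considered here, and "the series" means these few. Any claim that something is new, unique, unknown or untested is made for them only; others in the source may bear on it.

Compound 1 `O=C(/C=C/c1ccc([N+](=O)[O-])o1)c1ccc(N2CCCCC2)cc1` gives in an ADME assay on THP-1 cells (Homo sapiens) for cytotoxicity, read by resazurin assay, with a stated time of 72 h (on this read-out higher numbers stand for lower toxicity in this test and lower numbers for higher toxicity in this test), the limit > 50000 nM.
Compound 2 `O=C(/C=C/c1ccc([N+](=O)[O-])o1)c1ccc(N2CCNCC2)cc1` gives in this assay the limit > 50000 nM.

Both values are limits of the test, not numbers, and so the step that the two limits leave unreadable from compound 1 to compound 2 cannot be read; the limit of > 50000 nM in this assay, at which 2 of the 2 values shown sit, shows that both of the shown values sit at the same limit. Compound 2 therefore stands only at a limit, with no measured number of its own. The next compound, compound 3 `O=C(/C=C/c1ccc([N+](=O)[O-])o1)c1ccc(Br)cc1`, differs from compound 2 in one place: bromo in place of piperazin-1-yl on an aromatic carbon. No measured step bears on this exchange, because the only step shown, a step that the two limits leave unreadable from compound 1 to compound 2, is unreadable; its size in this assay cannot be foreseen from the data, in either direction. As a working guess, compound 3 is expected to give in this assay about 30000 nM, between 8000 nM and 100000 nM. That estimate corresponds to an expected step of an at least 1.6-fold lower number from compound 2 to compound 3 (0.22 log units; that floor lies within the scatter).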

Compound 3, half-maximal cytotoxic concentration: 13400 nM
Estimate against measurement, compound 3: 2.2-fold (0.35 log units) above, within the range that was stated.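

In this assay, this position on the shared core can change the read-out: bromo in place of piperazin-1-yl on an aromatic carbon gives an at least 3.7-fold lower number from compound 2 to compound 3 (0.57 log units; beyond the scatter), and bromo in place of piperidin-1-yl gives an at least 3.7-fold lower number from compound 1 to compound 3 (0.57 log units; beyond the scatter). Within the data shown here, both steps point towards higher toxicity in this test, and compound 3 supplies the first measured number. Each step has only a minimum size and the step between the two ring compounds cannot be read, since the values of those two compounds are limits of the test: the limit of > 50000 nM in this assay, at which 2 of the 3 values shown sit.

Going by these compounds, it remains open whether the change follows from bromo itself or from the departure of a six-membered ring. Chloro, methoxy or an open-chain dimethylamino group on the same carbon could separate these two readings.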